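Aryl amide fluoro to trifluoromethoxy swap: hepatocyte clearance

This account rests on a few compounds, and the source may have more. Where it says the series, first, only, none or still open, it means among the compounds named here.

Measured compounds in an ADME assay on cells (Hepatocyte, Rattus norvegicus) for metabolic stability; a lower number here means slower removal, a higher number faster removal of the compound:
- compound 1, `O=C(O)CCC(=O)N(C1CC1)[C@H]1c2ccccc2N(C(=O)c2cccc(OC(F)(F)F)c2)[C@H]2CC[C@H]21`: 15 uL/min
- compound 2, `O=C(O)COC(=O)N(C1CC1)[C@H]1c2ccccc2N(C(=O)c2ccc(F)cc2)[C@H]2CC[C@H]21`: 13 uL/min
- compound 3, `O=C(O)CCC(=O)N(C1CC1)[C@H]1c2ccccc2N(C(=O)c2cccc(F)c2)[C@H]2CC[C@H]21`: 16 uL/min

All three measured numbers sit close together; the difference between compound 2 and compound 3 spans more than one place and is not broken down here. Within the core of compound 3, the change trifluoromethoxy in place of fluoro on an aromatic carbon gives a 1.1-fold lower number from compound 3 to compound 1 (0.03 log units; within the scatter), a step that is indistinguishable from repeat scatter.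

Compound 4, `O=C(O)COC(=O)N(C1CC1)[C@H]1c2ccccc2N(C(=O)c2ccc(OC(F)(F)F)cc2)[C@H]2CC[C@H]21`, is unmeasured. It arises from compound 2 by trifluoromethoxy in place of fluoro on an aromatic carbon. This is the same kind of change as that from compound 3 to compound 1, not the same: in compound 1 the entering group sits meta to a large group, in compound 4 it sits para to a large group, and the core differs.

Among the measured compounds shown here, since the one measured instance of this swap moved the number by only a 1.1-fold lower number from compound 3 to compound 1 (0.03 log units; within the scatter), compound 4 is expected to stay near compound 2, with an estimated step of a 1.1-fold lower number from compound 2 to compound 4 (0.03 log units; within the scatter). Compound 4 is thus estimated at 12 uL/min in this assay, with a likely range of 7 uL/min to 22 uL/min.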

Compound 4, intrinsic clearance in a liver preparation (reported as CLH), per the amount of preparation that the assay uses: 18 uL/min
Compound 4: the middle estimate sits 1.5-fold (0.18 log units) below what was measured; measured number inside the range.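

In this assay, trifluoromethoxy in place of fluoro, here para to a large group, gives a 1.4-fold higher number from compound 2 to compound 4 (0.14 log units; within the scatter) and so stays within what repeat measurements would scatter by. Set beside the earlier instance of this change, the second step does not read as different from the first: the same change on two cores in this assay, a 1.1-fold lower number (0.03 log units; within the scatter) from compound 3 to compound 1 and a 1.4-fold higher number (0.14 log units; within the scatter) from compound 2 to compound 4, 1.5-fold (0.17 log units) apart, within the scatter of two such steps

So on these two cores the swap leaves the clearance number indistinguishable from that of the fluoro parent, and no core dependence can be read from the pair of steps. Among the compounds shown here, this does not show that the change is neutral in general, since only two pairs exist, and they differ both in the core and in the place of the group on the ring, so neither factor can be separated from the other.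

Every compound shown keeps a carboxylic acid at the end of the side chain and a cyclopropyl group on the nitrogen. From the compounds shown here alone, whether the swap stays this quiet with an amide or an amine in place of that acid, or with a longer chain, remains open.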